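Swapping one phenyl group on compound 1

The source may hold more compounds than are shown below. What is called first, only, known or untested is meant among the compounds shown, and "the series" means these compounds.

Measured in a physicochemical assay for solubility; on this read-out lower numbers stand for lower solubility and higher numbers for higher solubility:
- compound 1 `O=C(O)c1ccc(C(=O)/C(=C\c2ccc(O)c([N+](=O)[O-])c2)SCc2ccc(Br)cc2)cc1`: < 1000 ug/mL
- compound 2 `O=C(O)c1ccc(C(=O)/C(=C\c2ccc(F)c([N+](=O)[O-])c2)S(=O)(=O)Cc2ccc(Br)cc2)cc1`: < 1000 ug/mL
- compound 3 `O=C(O)c1ccc(C(=O)/C(=C\c2ccc(F)c([N+](=O)[O-])c2)SCc2ccc(C(F)(F)F)cc2)cc1`: < 1000 ug/mL

Compound 1 has no exact number in this assay, and its < 1000 ug/mL is only a limit. The same holds for the other two measured compounds, as the shared reading shows: the limit of < 1000 ug/mL in this assay, at which 3 of the 3 values shown sit. A limit like this gives a starting point but no ranking, so nothing can be said about order among these three compounds.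

The next compound to be measured is compound 4 `O=C(O)c1ccc(C(=O)/C(=C\c2ccc(F)cc2[N+](=O)[O-])SCc2ccc(Br)cc2)cc1`. It keeps the rest of compound 1 and carries 4-fluoro-2-nitrophenyl in place of 4-hydroxy-3-nitrophenyl on a double-bonded chain carbon bound to a double-bonded chain carbon.

Within the data shown here, no measured pair of compounds gives a step to lean on, so the expectation rests on the shared reading of compound 1 and its companions, (the limit of < 1000 ug/mL in this assay, at which 3 of the 3 values shown sit). The expected change is a step that the limit leaves unreadable from compound 1 to compound 4, which would be no step beyond the scatter, in either direction. Compound 4 is expected at about 800 ug/mL, with an estimated range from 300 ug/mL to 1000 ug/mL.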

Compound 4, solubility: < 1000 ug/mL
Compound 4 ended at the assay's limit; the forecaster's own chance of this, stated with the estimate: 85%; the middle value is on the limit's open side.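

No step can be read from compound 1 to compound 4, since both results in this assay are limits and not numbers: the limit of < 1000 ug/mL in this assay, at which 4 of the 4 values shown sit.

The compounds shown leave open how 4-fluoro-2-nitrophenyl and 4-hydroxy-3-nitrophenyl compare in this assay, and what exact number any of the four compounds would give.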